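From Fluoro to Chloro on the Pendant Phenyl Ring

This account rests on a few compounds, and the source may have more. Where it says the series, first, only, none or still open, it means among the compounds named here.

The two measured compounds share one core. Compound 1 `CC1=NC(C)=C(C(=O)O)C(c2ccccc2[N+](=O)[O-])/C1=C(\O)OC/C=C/c1ccccc1` bears a 2-nitrophenyl on a saturated ring carbon, and in a functional assay on IMR-32 cells for inhibition of Voltage-dependent N-type calcium channel subunit alpha-1B (Homo sapiens), read by calcium flux (on this read-out higher numbers stand for weaker inhibition and lower numbers for stronger inhibition), compound 1 gives 37000 nM. Compound 2 `CC1=NC(C)=C(C(=O)O)C(c2cccc(F)c2)/C1=C(\O)OC/C=C/c1ccccc1` carries 3-fluorophenyl in that place, and in this assay compound 2 gives 1300 nM, the lowest of the two numbers. Among the measured compounds shown here, the only measured step, a 28-fold lower number from compound 1 to compound 2 (1.45 log units; beyond the scatter), is large. Compound 3 `CC1=NC(C)=C(C(=O)O)C(c2cccc(Cl)c2)/C1=C(\O)OC/C=C/c1ccccc1` differs from compound 2 only by chloro in place of fluoro on an aromatic carbon. For the measured compounds named here, that measured step exchanges the whole aryl group and does not speak to a swap of one halogen for another at the same place; no measured pair reports such a swap. The expectation is therefore that compound 3 changes little, with a 1.3-fold lower number from compound 2 to compound 3 (0.11 log units; within the scatter) staying within the scatter. In this assay compound 3 is estimated at 1000 nM, in the range 300 nM to 4000 nM.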

Compound 3, half-maximal inhibitory concentration: 1000 nM
Estimate against measurement, compound 3: no gap at the digits printed; low and high end bracket the measured number.
By their numbers in this assay, from the lowest: compounds 3 and 2 (each within the scatter of the next); then compound 1.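

In this assay, chloro in place of fluoro on an aromatic carbon, meta to a large group, gives a 1.3-fold lower number from compound 2 to compound 3 (0.11 log units; within the scatter) and so does not separate the two halogens at this place. Among the compounds shown here, compound 1 had so far been compared with only one halogen compound, and the exchange of the whole aryl group now also gives a 37-fold lower number from compound 1 to compound 3 (1.57 log units; beyond the scatter) with the chloro member, so the large gap from the 2-nitrophenyl compound is seen with either halogen. Nothing available explains why the two halogens read alike or why compound 1 stands apart.

The compounds shown leave open whether bromo, methoxy or an amine at this place would stay near the two halogen compounds. On these data alone, it also stays open whether a larger group there, such as a trifluoromethyl, would keep the number in that range.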